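A pyridinyl hydrazone on a shared triazine core

This account rests on a few compounds, and the source may have more. Where it says the series, first, only, none or still open, it means among the compounds named here.

Two compounds share a core carrying a hydrazone arm. Compound 1 `NS(=O)(=O)c1ccc(Nc2nc(N/N=C/c3ccc(C(F)(F)F)cc3)nc(Nc3ccccc3)n2)cc1` gives 2170 nM in a functional assay on SK-MEL-2 cells (Homo sapiens) for inhibition, read by sulforhodamine B assay, with a stated time of 48 h; a higher number here means a weaker inhibitor of growth, a lower number a stronger inhibitor of growth. Compound 2 `Cc1nn(-c2ccccc2)cc1/C=N/Nc1nc(Nc2ccccc2)nc(Nc2ccc(S(N)(=O)=O)cc2)n1` gives 1690 nM in this assay. Compound 2 stands at the lower of the two numbers, but the step of a 1.3-fold lower number from compound 1 to compound 2 (0.11 log units; within the scatter) is within the scatter, so the two cannot be told apart. Compound 3 `NS(=O)(=O)c1ccc(Nc2nc(N/N=C/c3ccccn3)nc(Nc3ccccc3)n2)cc1` is not yet measured; it differs from compound 2 in one place: pyridin-2-yl in place of 3-methyl-1-phenyl-1H-pyrazol-4-yl on a carbon with a double bond to nitrogen. Among the measured compounds shown here, only one measured step touches this position, the exchange from compound 1 to compound 2, and it was a 1.3-fold lower number from compound 1 to compound 2 (0.11 log units; within the scatter), within the scatter. For the measured compounds named here, there is no measured compound bearing a pyridin-2-yl here, so nothing in the data points to a move in either direction beyond the scatter. Going by the values given here, the expected step from compound 2 to compound 3 is therefore a 1.2-fold higher number from compound 2 to compound 3 (0.07 log units; within the scatter), essentially no change beyond the scatter, with the range widened because the step of a 1.3-fold lower number from compound 1 to compound 2 (0.11 log units; within the scatter) is the sole guide. Compound 3 is estimated at 2000 nM in this assay, within 800 nM to 5000 nM.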

Compound 3, concentration for 50% growth inhibition: 1500 nM
Estimate against measurement, compound 3: 1.3-fold (0.12 log units) above; low and high end bracket the measured number.
By their numbers in this assay, from the lowest: compounds 3, 2 and 1 (each within the scatter of the next).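

In this assay, pyridin-2-yl gives a 1.1-fold lower number from compound 2 to compound 3 (0.05 log units; within the scatter) when it enters in place of 3-methyl-1-phenyl-1H-pyrazol-4-yl, and a 1.4-fold lower number from compound 1 to compound 3 (0.16 log units; within the scatter) when it enters in place of 4-(trifluoromethyl)phenyl. The earlier pair held only larger groups at this place on a carbon with a double bond to nitrogen, whereas compound 3 carries a six-membered aromatic ring with 1 hetero atom and has 6 heavy atoms in this group, fewer than the group in compound 2 has. Among these three compounds, then, neither the ring nitrogen of pyridin-2-yl nor the smaller size of the group separates the numbers beyond the scatter, so the three cannot be told apart here.

From the compounds shown here alone, what remains open is whether a different kind of group on this carbon, such as a ring bearing an amine or a carboxylic acid, or a longer open chain in place of a ring, would give a number clearly apart from these three. Nothing available offers a reason for the closeness of these numbers.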